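Working notes on the step from compound 3 to compound 4

This account rests on a few compounds, and the source may have more. Where it says the series, first, only, none or still open, it means among the compounds named here.

Three compounds share one core and differ only at the nitrogen that carries the methyl. Compound 1 `CC(=O)N(C)c1ccc2[nH]c(-c3n[nH]c4ccccc34)cc2n1` gives 5110 nM in a functional assay on HL-60 cells (Homo sapiens) for antiproliferative activity, read by MTT assay, with a stated time of 72 h; on this read-out lower numbers stand for stronger inhibition and higher numbers for weaker inhibition. Compound 2 `CN(C(=O)c1ccc(Br)cc1)c1ccc2[nH]c(-c3n[nH]c4ccccc34)cc2n1` gives 1080 nM in this assay. Compound 3 `CN(c1ccc2[nH]c(-c3n[nH]c4ccccc34)cc2n1)S(=O)(=O)c1ccc(Br)cc1` gives 6240 nM in this assay, the highest of the three numbers; its gap to compound 1 is within the scatter, whereas the step of a 5.8-fold higher number from compound 2 to compound 3 (0.76 log units; beyond the scatter) lies beyond it. Compound 4 `CN(C(=O)Nc1ccccc1)c1ccc2[nH]c(-c3n[nH]c4ccccc34)cc2n1` is not yet measured and differs from compound 3 in one place: phenylcarbamoyl in place of (4-bromophenyl)sulfonyl on a nitrogen on an aromatic ring. Among the measured compounds shown here, two measured steps bear on this. The step of a 5.8-fold higher number from compound 2 to compound 3 (0.76 log units; beyond the scatter) shows that a carbonyl in place of a sulfonyl on this nitrogen went with a clearly lower number, and the step of a 4.7-fold lower number from compound 1 to compound 2 (0.67 log units; beyond the scatter) shows that 4-bromophenyl in place of methyl on a carbonyl carbon also went with a lower number. For the measured compounds named here, compound 4 carries both a carbonyl and a phenyl, though joined through an added nitrogen for which no measured step exists, so the expected step of a 3.5-fold lower number from compound 3 to compound 4 (0.54 log units; beyond the scatter) is a modest fall in this assay with wide uncertainty. Compound 4 is expected to give 1800 nM, within 600 nM to 6000 nM.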

Compound 4, half-maximal inhibitory concentration: 8.3 nM
Estimate against measurement, compound 4: 220-fold (2.34 log units) above, and the stated range ends above it.
By their numbers in this assay, from the lowest: compound 4; then compound 2; then compounds 1 and 3 (each within the scatter of the next).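

The sulfonyl and carbonyl groups tried earlier on this nitrogen left the series in the micromolar range, but phenylcarbamoyl on the nitrogen on an aromatic ring gives a 750-fold lower number from compound 3 to compound 4 (2.88 log units; beyond the scatter) in this assay. Anilino on the carbonyl carbon is far more effective than the earlier groups there, with a 130-fold lower number from compound 2 to compound 4 (2.11 log units; beyond the scatter) and a 620-fold lower number from compound 1 to compound 4 (2.79 log units; beyond the scatter), so a carbonyl bearing an aromatic ring does not on its own reach this level. Nothing available explains the size of these steps.

The step with anilino adds a nitrogen and also removes the bromine, so the two changes cannot be told apart here, and a 4-bromoanilino group would separate them. On these data alone, whether the phenyl ring is needed at all remains open, which a methylamino or benzylamino group on the same carbonyl would address.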